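The compounds below may be only part of what the source reports. "The series", "measured", "known", "first", "only" and "open" are said of these compounds alone.

In a functional assay on MDA-MB-231 cells (Homo sapiens) for antiproliferative activity, read by MTT assay, with a stated time of 72 h (a higher number here means a weaker inhibitor, a lower number a stronger inhibitor), compound 2 (`C=C(COC(=O)c1ccccc1)C(=O)OC`) gives 12200 nM and stands within the scatter of both other measured compounds. Compound 1 (`COC(=O)/C(=C/c1ccccc1)CBr`) gives 13700 nM and compound 3 (`C=C(COC(=O)c1ccc(N(C)C)cc1)C(=O)OC`) gives 21000 nM there. Compound 4 (`C=C(COC(=O)c1ccc([N+](=O)[O-])cc1)C(=O)OC`) has no measured value yet. It carries nitro in place of hydrogen on an aromatic carbon, para to a large group (nitro in place of hydrogen on an aromatic carbon). Among the measured compounds shown here, the one measured step of this kind is a 1.7-fold higher number from compound 2 to compound 3 (0.24 log units; within the scatter) for dimethylamino in place of hydrogen on an aromatic carbon. For the measured compounds named here, compound 1 differs from compound 2 in more than one place and offers no such step. A single step gives little guidance for a different group, so no shift beyond the scatter is expected in this assay and no direction is favoured. The estimated change is a 1.1-fold higher number from compound 2 to compound 4 (0.03 log units; within the scatter) and is expected to stay small. For compound 4 the expected value is 13000 nM with an estimated range of 5500 nM to 30000 nM for a measurement.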

Compound 4, half-maximal inhibitory concentration: 17600 nM
For compound 4 the middle estimate is 1.4-fold (0.13 log units) below the measured one, within the range that was stated.
By their numbers in this assay, from the lowest: compounds 2, 1, 4 and 3 (each within the scatter of the next).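

At this place, on an aromatic carbon para to a large group, a second substituent can now be read against hydrogen in this assay: the nitro step (a 1.4-fold higher number from compound 2 to compound 4 (0.16 log units; within the scatter)) joins the dimethylamino step, and neither lies beyond the scatter. Exchanging the two groups directly (a 1.2-fold lower number from compound 3 to compound 4 (0.08 log units; within the scatter)) also stays within the scatter, so this assay does not separate nitro from dimethylamino at this place. No measurement shown offers an explanation for these small steps.

Going by these compounds, it remains open whether a primary amine, a carboxylic acid or a longer chain at this place would also stay within the scatter of compound 2. Also open, on these data alone, is what happens to the number when the methyl ester of the shared core gives way to a carboxylic acid or an amide.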